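Shortening a Butyl Chain in a Biguanide Series

A few compounds are considered here, and "the series" means these few. Any claim that something is new, unique, unknown or untested is made for them only; others in the source may bear on it.

Of the compounds shown here, three have been measured in a physicochemical assay for lipophilicity, in phosphate buffer, measured as octanol-water partition, at pH 11.5; on this read-out higher numbers stand for higher lipophilicity and lower numbers for lower lipophilicity. Compound 1, `CCCCS(=O)(=O)c1ccc(NC(=N)NC(=N)NCCCCCCNC(=N)NC(=N)Nc2ccc(S(=O)(=O)CCCC)cc2)cc1`, gives 3.1. Compound 2, `CCCCC(CC)CNC(=N)NC(=N)Nc1ccc(C)cc1`, gives 4.73. Compound 3, `CCCCNC(=N)NC(=N)Nc1ccc(Cl)cc1`, gives 3.13. Among these three numbers compound 3 stands second highest: its value and that of compound 1 lie within the scatter of each other, so nothing can be said about their order, while compound 2 lies higher than compound 3 by an amount beyond the scatter.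

Compound 4, `CCCNC(=N)NC(=N)Nc1ccc(Cl)cc1`, has not yet been measured in this assay. It differs from compound 3 in one place: hydrogen in place of methyl on a saturated chain carbon, three bonds along the chain from an amine nitrogen. Within the data shown here, no pair of measured compounds differs by this same change, so there is no measured step to lean on; the expectation rests on the general run of such butyl-to-propyl pairs.

Compound 4 is expected to come out lower than compound 3 in this assay, by a step of a number 0.53 log units lower from compound 3 to compound 4 (beyond the scatter), which would lie a little beyond the scatter. Compound 4 is therefore estimated at 2.6, with a range from 2.2 to 3.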

Compound 4, partition coefficient: 2.63
Beside the measured number, compound 4's estimate is 0.03 log units below it; measured number inside the range.
By their numbers in this assay, from the lowest: compound 4; then compounds 1 and 3 (each within the scatter of the next); then compound 2.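

In this assay the series now has its first measured step at this position: hydrogen in place of methyl on a saturated chain carbon, three bonds along the chain from an amine nitrogen, gives a number 0.50 log units lower from compound 3 to compound 4 (beyond the scatter). The earlier compounds shown here offered no pair differing in one place, so until now nothing separated the effect of this butyl to propyl change from the other differences among them; this pair isolates it on a single shared core and shows that removing this one carbon moves the read-out by more than the usual scatter. Nothing in hand explains the size of this step, which remains an observation from one pair of compounds.

The compounds shown leave open whether a shorter ethyl or methyl chain in the same place would extend the fall, and whether a longer pentyl chain would reverse it in this assay. They also leave open how a hydroxyl or an amine at the end of the chain would read, and whether this step would keep its size on a core carrying a different group.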